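From one bromine to two chlorines: a small expected step

The source may report more compounds than this note shows. Statements on the series, on what has been measured and on what is new or still open speak of the compounds shown alone.

- compound 1 `CNC(=O)c1cc(Oc2ccc(C(=O)/C=C/c3ccc(Br)cc3)cc2)ccn1` gives 18500 nM
- compound 2 `CNC(=O)c1cc(Oc2ccc(/C=C/C(=O)c3ccc(Br)cc3)cc2)ccn1` gives 3560 nM

In a functional assay on PC-3 cells (Homo sapiens) for cytotoxicity, read by MTT assay, with a stated time of 72 h (a lower number here means a stronger inhibitor, a higher number a weaker inhibitor), compound 1 (18500 nM) has the higher of the two numbers. Compound 2 (3560 nM) sits lower by more than the usual scatter of repeated measurements, which leaves compound 1 as the weaker inhibitor of this pair.

Compound 3 `CNC(=O)c1cc(Oc2ccc(C(=O)/C=C/c3ccc(Cl)cc3Cl)cc2)ccn1` keeps the core of compound 1 but carries 2,4-dichlorophenyl in place of 4-bromophenyl on a double-bonded chain carbon bound to a double-bonded chain carbon. Among the measured compounds shown here, no measured pair shows what this swap does, so the expectation starts from compound 1 (18500 nM). The expected step (a 1.5-fold lower number from compound 1 to compound 3 (0.19 log units; within the scatter)) is small, leaning towards a lower number but staying within the scatter. For compound 3 the estimated value is 12000 nM with an expected range from 5000 nM to 30000 nM in repeat measurements.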

Compound 3, half-maximal inhibitory concentration: 9220 nM
For compound 3 the middle estimate is 1.3-fold (0.11 log units) above the measured one, within the range that was stated.
By their numbers in this assay, from the lowest: compound 2; then compounds 3 and 1 (each within the scatter of the next).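

Among the compounds shown here, this is the first direct reading of a change at this place, on a double-bonded chain carbon bound to a double-bonded chain carbon, with the shared core held constant. In this assay, 2,4-dichlorophenyl in place of 4-bromophenyl gives a 2.0-fold lower number from compound 1 to compound 3 (0.30 log units; within the scatter), so the two groups cannot be told apart here, even though one bromine leaves and two chlorines enter. No measurement of any property of these groups is available to bear on this result.

Because the swap alters both the halogen and the number of halogens, the compounds shown do not separate these two changes, and 4-chlorophenyl would be the simplest group to test this. They also leave open whether a phenyl ring carrying an amine or a carboxylic acid at this place would move the number beyond the scatter.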